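The compounds below may be only part of what the source reports. "The series", "measured", "known", "first", "only" and "open" are said of these compounds alone.

Compound 1 `O=C(/C=C/c1ccc(Oc2ncnc3ccc(Cl)cc23)cc1)/C=C/c1c(Cl)cccc1Cl` gives 61.7% in a functional assay on MGC-803 cells (Homo sapiens) for inhibition, read by MTT assay, with a stated time of 72 h, tested at 10 uM; a higher number here means more inhibition of growth at the concentration tested, a lower number less inhibition of growth.
Compound 2 `O=C(/C=C/c1cc([N+](=O)[O-])ccc1Cl)/C=C/c1ccccc1Oc1ncnc2ccc(Cl)cc12` gives 91.6% in this assay.
Compound 3 `O=C(/C=C/c1ccc(Cl)c(Cl)c1)/C=C/c1ccccc1Oc1ncnc2ccc(Cl)cc12` gives 56.7% in this assay.

Among these three, compound 1 stands second highest: its nearest neighbour is compound 3, which lies lower but within the scatter, while compound 2 sits far higher, beyond the scatter. Compound 4 `O=C(/C=C/c1ccc(Oc2ncnc3ccc(Cl)cc23)cc1)/C=C/c1ccc(Cl)c(Cl)c1` is not yet measured. It differs from compound 1 in one place: 3,4-dichlorophenyl in place of 2,6-dichlorophenyl on a double-bonded chain carbon bound to a double-bonded chain carbon; cut one bond further out, the same change reads 2-(2,6-dichlorophenyl)ethenyl to 2-(3,4-dichlorophenyl)ethenyl. Within the data shown here, no measured step exchanges these two dichlorophenyl groups directly. Among the measured compounds shown here, the only step that touches the entering group is a number 34.9 percentage points lower from compound 2 to compound 3 (beyond the scatter), and it starts from a different group, so it says little about compound 4. What can be said is that compound 3 carries the entering group on a related core and its value lies within the scatter of compound 1. Compound 4 is therefore expected to change by about a number 4.7 percentage points lower from compound 1 to compound 4 (within the scatter), nothing beyond the scatter. The estimate for compound 4 is 57%, expected to fall between 35% and 78%.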

Compound 4, percent growth inhibition at one concentration: 50.5%
For compound 4 the middle estimate is 6.5 percentage points above the measured one; the range from low to high includes it.
By their numbers in this assay, from the lowest: compounds 4, 3 and 1 (each within the scatter of the next, the first and the last beyond it); then compound 2.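

In this assay, among these compounds, replacing 2,6-dichlorophenyl with 3,4-dichlorophenyl on a double-bonded chain carbon bound to a double-bonded chain carbon gives a number 11.2 percentage points lower from compound 1 to compound 4 (beyond the scatter), the first direct reading of this exchange on the core of compound 1. The two groups match in heavy atoms, ring and counted donors and acceptors, so the number at this position moves with the arrangement of the same atoms and not with any change in composition. No available evidence accounts for the difference.

The compounds shown leave open how this position on the core of compound 1 would take a phenyl bearing a methoxy group or an amine, or a phenyl with no chlorine at all. They also leave open whether 2-chloro-5-nitrophenyl would give a higher number on this core than either dichlorophenyl group.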